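Swapping Amino for Sulfanyl on Compound 2

This account rests on a few compounds, and the source may have more. Where it says the series, first, only, none or still open, it means among the compounds named here.

In a functional assay on L1210 cells (Mus musculus) for inhibition (on this read-out lower numbers stand for stronger inhibition and higher numbers for weaker inhibition), compound 1 `C=C1C(n2ccc(N)nc2=O)O[C@H](CO)[C@@H]1O` gives 2000 nM as its reading. Compound 2 `C=C1[C@@H](O)[C@H](n2cnc3c(N)nc(N)nc32)O[C@@H]1CO` stands at > 200000 nM in this assay and that reading is a limit of the assay, not a number. Its true position is therefore unknown, and any step away from it has an uncertain size.

Going by the values given here, compound 3 `C=C1[C@@H](O)[C@H](n2cnc3c(S)nc(N)nc32)O[C@@H]1CO` keeps the rest of compound 2 but carries sulfanyl in place of amino on an aromatic carbon as its single change. Among the compounds with values here, no measured pair shows this swap, so the expectation rests on the change itself and on compound 1 at 2000 nM as the only true number available.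

A large move toward stronger inhibition is expected, with an at least 10-fold lower number from compound 2 to compound 3 (1.00 log units; beyond the scatter) as the estimated step. For compound 3 the estimated value is 20000 nM with a range from 2500 nM to 150000 nM expected to hold most repeat measurements.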

Compound 3, half-maximal inhibitory concentration: 207000 nM
The estimate for compound 3 lay 10-fold (1.01 log units) below the measured number, and the stated range ends below it.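

No step from compound 2 to compound 3 can be read, because the reading for compound 2 is a limit of the assay and not a number: the limit of > 200000 nM in this assay, at which 1 of the 3 values shown sits.

The compounds shown leave open whether sulfanyl in place of amino on an aromatic carbon changes inhibition in this assay at all, and in which direction.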